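A Benzyl Amide Swap in Two Weak Antiproliferative Compounds

A few compounds are considered here, and "the series" means these few. Any claim that something is new, unique, unknown or untested is made for them only; others in the source may bear on it.

Compound 1, `Cc1ccc(CNC(=O)c2cccc(C(C)Oc3cccnc3Nc3cnn(CC#N)c3)c2)cc1`: in a functional assay on HCC78 cells (Homo sapiens) for antiproliferative activity, read by MTT assay, with a stated time of 48 h (on this read-out lower numbers stand for stronger inhibition and higher numbers for weaker inhibition), compound 1 gives 57400 nM.
Compound 2, `COc1cccc(CNC(=O)c2cccc(C(C)Oc3ccnc(Nc4cnn(C)c4)c3)c2)c1`: in this assay compound 2 gives 64400 nM.

Both numbers lie in the same weak range, and the gap between compound 2 and compound 1 is within the scatter of repeated measurements, so compound 2 stands level with compound 1 rather than apart from it. Among the measured compounds shown here, the two compounds also differ at several places at once, so no single step between measured compounds is available.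

Compound 3, `CC(Oc1ccnc(Nc2cnn(C)c2)c1)c1cccc(C(=O)NCc2ccc(C#N)cc2)c1`, is the next compound and differs from compound 2 in one place only: 4-cyanophenyl in place of 3-methoxyphenyl on a saturated chain carbon bound to an amide-type nitrogen. The shared core and the rest of the amide side chain stay as in compound 2.

For the measured compounds named here, nothing measured so far covers this particular change. Given how close compound 1 and compound 2 sit despite their several differences, the expectation for compound 3 in this assay is a step of a 1.1-fold lower number from compound 2 to compound 3 (0.03 log units; within the scatter), that is, no change beyond the scatter in either direction. Compound 3 is therefore estimated at 60000 nM, with a plausible range from 25000 nM to 150000 nM.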

Compound 3, half-maximal inhibitory concentration: 8700 nM
The estimate for compound 3 lay 6.9-fold (0.84 log units) above the measured number; the measured number lies below the stated range.
By their numbers in this assay, from the lowest: compound 3; then compounds 1 and 2 (each within the scatter of the next).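

Compound 3 shows that the group on the saturated chain carbon bound to an amide-type nitrogen is not a silent part of this series: in this assay, 4-cyanophenyl in place of 3-methoxyphenyl gives a 7.4-fold lower number from compound 2 to compound 3 (0.87 log units; beyond the scatter). Among the compounds shown here, compound 1 and compound 2 differ at several places at once, so they could not give a reading of this place alone, and this step is the first to do so. The two groups match in heavy atom count, ring type, hydrogen-bond donors, hydrogen-bond acceptors and net charge, so these counts do not separate them, and no measurement shown here accounts for the difference in activity.

Because the change replaces the methoxy group with a nitrile and also moves the substituent from the 3-position to the 4-position, the compounds shown cannot tell whether the group or its ring position matters more. They also leave open how a carboxylic acid or an amine on this phenyl ring would read in this assay, and whether the same change would carry over to the core of compound 1.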